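A Sulfonamide Swap on a Pyrimidine Kinase Scaffold

A few compounds are considered here, and "the series" means these few. Any claim that something is new, unique, unknown or untested is made for them only; others in the source may bear on it.

Compound 1 `CC[C@@H]1C(=O)N(C)c2cnc(Nc3ccc(S(=O)(=O)NC4CCCC4)cc3)nc2N1C1CCCC1` is the stronger of the two measured compounds: in a functional assay on K562 cells (Homo sapiens) for antiproliferative activity, read by CCK-8 assay, with a stated time of 72 h (a lower number here means a stronger inhibitor of growth, a higher number a weaker inhibitor of growth), compound 1 gives 872 nM. Compound 2 `CCC1C(=O)N(C)c2cnc(Nc3ccc(S(=O)(=O)NCCCO)cc3)nc2N1c1ccn(C)n1` differs from compound 1 in several places at once. In this assay compound 2 gives 13400 nM, a gap from compound 1 that lies beyond the scatter. Compound 3 `CC[C@@H]1C(=O)N(C)c2cnc(Nc3ccc(S(=O)(=O)NCCCO)cc3)nc2N1C1CCCC1` keeps the core of compound 1 and changes only the sulfonamide: 3-hydroxypropyl in place of cyclopentyl on a sulfonamide nitrogen. Without a measured single-point step of this kind, the step from compound 1 to compound 3 is expected to be a modest loss, a 2.3-fold higher number from compound 1 to compound 3 (0.36 log units; beyond the scatter). Compound 3 is therefore estimated at 2000 nM in this assay, within a range of 700 nM to 6000 nM.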

Compound 3, concentration for 50% growth inhibition: 331 nM
Beside the measured number, compound 3's estimate is 6.0-fold (0.78 log units) above it; the whole stated range lies above it.
By their numbers in this assay, from the lowest: compound 3; then compound 1; then compound 2.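

Placing 3-hydroxypropyl in place of cyclopentyl on a sulfonamide nitrogen gives in this assay a 2.6-fold lower number from compound 1 to compound 3 (0.42 log units; beyond the scatter) and so improves growth inhibition. With the core of compound 1 held fixed, this position accepts an open chain bearing a hydroxyl in place of a carbon-only ring, which the several changes separating compound 2 from compound 1 could not show. No measurement shown here explains this gain.

Whether the hydroxyl or the open chain accounts for the step remains open. A plain propyl chain, a longer hydroxyalkyl chain or a terminal amine on this nitrogen would help separate the two.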